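Swapping the aryl amine headgroup on the shared core

The source may report more compounds than this note shows. Statements on the series, on what has been measured and on what is new or still open speak of the compounds shown alone.

Among the compounds with values here, compound 2 `COc1ncc(-c2ccc3ncnc(Nc4ccc(OCCO)nc4)c3c2)cc1NS(=O)(=O)c1ccc(F)cc1F` stands with the higher of the two numbers so far in a functional assay on HCT-116 cells (Homo sapiens) for antiproliferative activity, read by sulforhodamine B assay, with a stated time of 72 h (a higher number here means a weaker inhibitor, a lower number a stronger inhibitor), giving 2340 nM, while compound 1 `COc1ncc(-c2ccc3ncnc(Nc4cnn(CCCO)c4)c3c2)cc1NS(=O)(=O)c1ccc(F)cc1F` gives 480 nM. Compound 3 `COc1cc(Nc2ncnc3ccc(-c4cnc(OC)c(NS(=O)(=O)c5ccc(F)cc5F)c4)cc23)ccc1OCCO` differs from compound 2 only in one place: 4-(2-hydroxyethoxy)-3-methoxyphenyl in place of 6-(2-hydroxyethoxy)pyridin-3-yl on a nitrogen on an aromatic ring. Within the data shown here, the single step in hand, a 4.9-fold higher number from compound 1 to compound 2 (0.69 log units; beyond the scatter), shows that this headgroup moves the number by a modest amount, but no measured pair covers a pyridine-to-phenyl change. Compound 3 is therefore expected to land near compound 2 with a slight downward lean, an estimated 1.7-fold lower number from compound 2 to compound 3 (0.22 log units; within the scatter), giving an estimate of 1400 nM with a range of 400 nM to 4500 nM.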

Compound 3, half-maximal inhibitory concentration: 5720 nM
Estimate against measurement, compound 3: 4.1-fold (0.61 log units) below; measured number above the stated range.
By their numbers in this assay, from the lowest: compound 1; then compound 2; then compound 3.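

In this assay, the change to 4-(2-hydroxyethoxy)-3-methoxyphenyl gave a 2.4-fold higher number from compound 2 to compound 3 (0.39 log units; beyond the scatter) and so moved the number even though both groups carry a 2-hydroxyethoxy substituent. Within the data shown here, measured against the 1-(3-hydroxypropyl)-1H-pyrazol-4-yl group, the same headgroup gave a 12-fold higher number from compound 1 to compound 3 (1.08 log units; beyond the scatter) and so the largest step at this position so far. No evidence at hand accounts for this order. The compounds shown leave open whether the ring carbon replacing the ring nitrogen or the added methoxy carries the step from the pyridine. They also leave open how an amine in place of the terminal hydroxyl would read here.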